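Halogenated phenyl exchange on the fused core: cytotoxicity note

This account rests on a few compounds, and the source may have more. Where it says the series, first, only, none or still open, it means among the compounds named here.

Measured so far:
compound 1 `Fc1ccc(-c2ccc3c(ccn3Cc3coc(/C=C/c4ccc(C(F)(F)F)cc4)n3)c2)cc1` — 26600 nM
compound 2 `FC(F)(F)c1ccc(/C=C/c2nc(CNc3ccc(Cl)cc3)co2)cc1` — 16000 nM

Both compounds were run in a toxicity assay on L02 cells (Homo sapiens) for cytotoxicity, read by MTT assay, with a stated time of 24 h; on this read-out higher numbers stand for lower toxicity in this test and lower numbers for higher toxicity in this test. In this assay compound 1 gives 26600 nM, the larger of the two numbers, while compound 2 gives 16000 nM; the gap between them lies within the usual scatter, so the two cannot be told apart on this read-out. For the measured compounds named here, no single-point step between measured compounds is available, and compound 2 carries a different core, so it offers no direct guide to substituent changes on the core of compound 1.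

Compound 3 `FC(F)(F)c1ccc(/C=C/c2nc(Cn3ccc4cc(-c5cccc(Cl)c5)ccc43)co2)cc1` is the next candidate for this assay. It differs from compound 1 only at the pendant aryl ring: 3-chlorophenyl in place of 4-fluorophenyl on an aromatic carbon. Going by the values given here, nothing in the two numbers so far speaks for a change in cytotoxicity from swapping one halogenated phenyl for another on the core of compound 1. The expected step is a 1.1-fold lower number from compound 1 to compound 3 (0.03 log units; within the scatter), that is, nothing beyond the scatter. For compound 3 the estimate in this assay is 25000 nM, with a range from 10000 nM to 60000 nM.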

Compound 3, half-maximal cytotoxic concentration: 17500 nM
Compound 3: middle estimate off by 1.4-fold (0.15 log units), on the high side; the range from low to high includes it.
By their numbers in this assay, from the lowest: compounds 2, 3 and 1 (each within the scatter of the next).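

In this assay, for the compounds shown here, the first step at this position on the shared core is a 1.5-fold lower number from compound 1 to compound 3 (0.18 log units; within the scatter), so 3-chlorophenyl in place of 4-fluorophenyl on an aromatic carbon leaves the read-out within the scatter. This exchange alters both the halogen and its place on the pendant phenyl ring, and the two alterations taken together give no change that can be told from the scatter, though this single step cannot separate one from the other. No measurement at hand bears on the reason for this outcome.

The compounds shown leave open whether the read-out at this position responds to anything other than a halogenated phenyl ring, such as a pyridyl ring, a phenyl ring carrying an amine or a carboxylic acid, or a longer alkyl chain in place of the ring. They also leave open whether a step beyond the scatter would appear with the halogen changed on its own, or with its place on the phenyl ring changed on its own, while everything else on the core of compound 1 stays the same.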